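A few compounds are considered here, and "the series" means these few. Any claim that something is new, unique, unknown or untested is made for them only; others in the source may bear on it.

Measured in an ADME assay on Vero cells (Chlorocebus sabaeus) for cytotoxicity, read by fluorescence and resazurin assay, with a stated time of 3 days; on this read-out lower numbers stand for higher toxicity in this test and higher numbers for lower toxicity in this test:

compound 1 `CC(=O)C[C@H]1O[C@@H](On2cc(CN3C(=O)/C(=N\Nc4ccc(F)cc4)c4ccccc43)nn2)[C@H](OC(C)=O)[C@@H](OC(C)=O)[C@@H]1OC(C)=O`: 68700 nM
compound 2 `CC(=O)C[C@H]1O[C@@H](On2cc(CN3C(=O)/C(=N\Nc4cccc(Cl)c4)c4ccccc43)nn2)[C@H](OC(C)=O)[C@@H](OC(C)=O)[C@@H]1OC(C)=O`: 117000 nM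
compound 3 `O=C1/C(=N\Nc2ccc(F)cc2)c2ccccc2N1Cc1cn(O[C@@H]2O[C@H](CO)[C@H](O)[C@H](O)[C@H]2O)nn1`: 92100 nM

Compound 4 `O=C1/C(=N\Nc2cccc(Cl)c2)c2ccccc2N1Cc1cn(O[C@@H]2O[C@H](CO)[C@H](O)[C@H](O)[C@H]2O)nn1` has not yet been measured in this assay. It differs from compound 3 by 3-chlorophenyl in place of 4-fluorophenyl on an amine nitrogen. The same change, at the same place, separates compound 1 from compound 2, where it gave a 1.7-fold higher number from compound 1 to compound 2 (0.23 log units; within the scatter). How the core of compound 1 differs from the core of compound 3 is not broken down here. Since the two changes read alike word for word, the step from compound 3 to compound 4 is expected to be of similar size, resting on a 1.7-fold higher number from compound 1 to compound 2 (0.23 log units; within the scatter). Compound 4 is therefore estimated at a 1.4-fold higher number from compound 3 to compound 4 (0.15 log units; within the scatter). The expected value for compound 4 is 130000 nM, likely between 65000 nM and 260000 nM.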

Compound 4, half-maximal cytotoxic concentration: 84500 nM
Compound 4: middle estimate off by 1.5-fold (0.19 log units), on the high side; the range from low to high includes it.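

In this assay putting 3-chlorophenyl in place of 4-fluorophenyl gives a 1.1-fold lower number from compound 3 to compound 4 (0.04 log units; within the scatter) and so stays as small as repeat measurements would scatter. Set beside the same change on the other core, the two steps cannot be told apart: the same change on two cores in this assay, a 1.7-fold higher number (0.23 log units; within the scatter) from compound 1 to compound 2 and a 1.1-fold lower number (0.04 log units; within the scatter) from compound 3 to compound 4, 1.9-fold (0.27 log units) apart, within the scatter of two such steps. The change therefore carries from one core to the other in the limited sense that neither core shows a step beyond the scatter, but this does not show that the change has a real effect on either core or that the two cores respond alike.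

Going by these compounds, only these two groups are compared on the amine nitrogen, so a plain phenyl or a pyridine ring there remains open. On these data alone, whether the same holds on further cores also remains open.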